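Butoxy in place of butyl on an aromatic carbon

The source may report more compounds than this note shows. Statements on the series, on what has been measured and on what is new or still open speak of the compounds shown alone.

Of the compounds shown here, three have been measured in a functional assay on MCF7 cells (Homo sapiens) for antiproliferative activity, read by sulforhodamine B assay, with a stated time of 48 h; on this read-out lower numbers stand for stronger inhibition and higher numbers for weaker inhibition: compound 1 `CCc1ccccc1NS(=O)(=O)c1ccc(N2CCNC2=O)cc1` (350 nM), compound 2 `O=C1NCCN1c1ccc(S(=O)(=O)Nc2ccc3[nH]ccc3c2)cc1` (170 nM) and compound 3 `CCCCc1ccc(NS(=O)(=O)c2ccc(N3CCNC3=O)cc2)cc1` (770 nM). Compound 3 has the highest number of the three and is therefore the weakest, with its value beyond the scatter from both of the others. Compound 4 `CCCCOc1ccc(NS(=O)(=O)c2ccc(N3CCNC3=O)cc2)cc1` keeps the shared core but carries butoxy in place of butyl on an aromatic carbon, para to a large group (butoxy in place of butyl on an aromatic carbon). Within the data shown here, no measured pair shows this change, so no step beyond the scatter is expected in this assay and the direction remains open. The estimated step of a 1.4-fold lower number from compound 3 to compound 4 (0.15 log units; within the scatter) stays within that scatter. Compound 4 is estimated at 550 nM (expected range 200 nM to 1300 nM).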

Compound 4, half-maximal inhibitory concentration: 870 nM
Compound 4: middle estimate off by 1.6-fold (0.20 log units), on the low side; the measured number falls inside the stated range.
By their numbers in this assay, from the lowest: compound 2; then compound 1; then compounds 3 and 4 (each within the scatter of the next).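

In this assay, butoxy in place of butyl on an aromatic carbon, para to a large group, gives a 1.1-fold higher number from compound 3 to compound 4 (0.05 log units; within the scatter). Among these compounds, this is the first step read at this position, and the numbers of the two compounds cannot be told apart, so the added oxygen and its hydrogen-bond acceptor give no measurable difference here. No measurement of any property of these compounds is available to explain this result. The compounds shown leave open whether an amine, a carboxylic acid or a longer chain such as hexyloxy at this position would move the number beyond the scatter.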